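Adding one chain carbon to compound 3

The source may report more compounds than this note shows. Statements on the series, on what has been measured and on what is new or still open speak of the compounds shown alone.

Compound 1 `O=C(O)c1cc(CCCCCCNS(=O)(=O)c2ccccc2)c2cccccc1-2`: 140 nM
Compound 2 `O=C(O)c1cc(CCCCCCCNS(=O)(=O)c2ccccc2)c2cccccc1-2`: 18 nM
Compound 3 `CC(C)c1cccc2c(CCCCCCNS(=O)(=O)c3ccccc3)cc(C(=O)O)c-2c1`: 920 nM

All three values come from a functional assay (thoracic aorta) for inhibition, with Rattus norvegicus as the target; a lower number here means a stronger inhibitor, a higher number a weaker inhibitor. Compound 3 carries the highest number of the three, at 920 nM. Compound 4 `CC(C)c1cccc2c(CCCCCCCNS(=O)(=O)c3ccccc3)cc(C(=O)O)c-2c1` differs from it by ((phenylsulfonyl)amino)methyl in place of (phenylsulfonyl)amino on a saturated chain carbon, six bonds along the chain from an aromatic carbon, with ((phenylsulfonyl)amino)methyl in place of (phenylsulfonyl)amino on a saturated chain carbon, six bonds along the chain from an aromatic carbon.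

Within the data shown here, the only measured step, a 6.6-fold higher number from compound 1 to compound 3 (0.82 log units; beyond the scatter), is modest and concerns isopropyl in place of hydrogen on an aromatic carbon, not this chain change. The closest guide is the pair without isopropyl: compound 1 gives 140 nM and compound 2 gives 18 nM, the lower number. A similar move to a lower number in this assay is therefore expected, an estimated 7.7-fold lower number from compound 3 to compound 4 (0.88 log units; beyond the scatter). The estimate for compound 4 is 120 nM, with an expected range of 40 nM to 400 nM.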

Compound 4, half-maximal inhibitory concentration: 930 nM
Beside the measured number, compound 4's estimate is 7.8-fold (0.89 log units) below it; the measured number lies above the stated range.
By their numbers in this assay, from the lowest: compound 2; then compound 1; then compounds 3 and 4 (each within the scatter of the next).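

In this assay, ((phenylsulfonyl)amino)methyl in place of (phenylsulfonyl)amino on the isopropyl-bearing core gives no separable difference, a 1.0-fold higher number from compound 3 to compound 4 (0.00 log units; within the scatter), so the gap between compound 1 at 140 nM and compound 2 at 18 nM does not carry over to this core. Isopropyl in place of hydrogen on an aromatic carbon costs far more with the longer chain, a 52-fold higher number from compound 2 to compound 4 (1.71 log units; beyond the scatter). The isopropyl change and the chain length therefore do not act independently: the same change on two cores in this assay, a 6.6-fold higher number (0.82 log units; beyond the scatter) from compound 1 to compound 3 and a 52-fold higher number (1.71 log units; beyond the scatter) from compound 2 to compound 4, 7.9-fold (0.90 log units) apart, beyond the scatter of two such steps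

The reason for this dependence stays open. So does whether methyl in place of isopropyl, or a longer chain, would restore the chain effect.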